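This account rests on a few compounds, and the source may have more. Where it says the series, first, only, none or still open, it means among the compounds named here.

Of the compounds shown here, three have been measured in an ADME assay on microsomes from liver (Mus musculus, strain NMRI) for metabolic stability, tested at 2.5 uM; on this read-out higher numbers stand for fast clearance and lower numbers for slow clearance. Compound 1 `Fc1cc(Cl)ccc1-c1ccc(Cn2nnc3ccccc32)cn1` gives 3.4 mL/min/g, compound 2 `Brc1cccc2c1nnn2Cc1ccccc1` gives 2.3 mL/min/g, and compound 3 `Fc1ccccc1Cn1nnc2c(Br)cccc21` gives 1.7 mL/min/g. Compound 3 therefore sits at the bottom of the three numbers, but since compound 2 is only a 1.4-fold lower number from compound 2 to compound 3 (0.13 log units; within the scatter) away and compound 1 is within the usual scatter as well, the three values cannot be told apart with confidence.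

Compound 4 `Fc1cc(Cl)ccc1Cn1nnc2c(Br)cccc21` differs from compound 3 by chloro in place of hydrogen on an aromatic carbon. Within the data shown here, the one measured step that might guide expectations is the change from compound 2 to compound 3, which added a fluoro group and moved the number by a 1.4-fold lower number from compound 2 to compound 3 (0.13 log units; within the scatter); no measured step adds a chloro group to this core. Compound 1 carries both a fluoro and a chloro group, yet on a different core, and its value stays within scatter of compound 3. The change to compound 4 is thus expected to give a 1.2-fold higher number from compound 3 to compound 4 (0.07 log units; within the scatter), nothing beyond scatter. Compound 4 is estimated at 2 mL/min/g, with a range from 1 mL/min/g to 4 mL/min/g.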

Compound 4, intrinsic clearance in a liver preparation (reported as CLH), per the amount of preparation that the assay uses: 1.3 mL/min/g
The estimate for compound 4 lay 1.5-fold (0.19 log units) above the measured number; the range from low to high includes it.
By their numbers in this assay, from the lowest: compounds 4, 3, 2 and 1 (each within the scatter of the next, the first and the last beyond it).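

In this assay, chloro in place of hydrogen on the six-membered aromatic ring, meta to a fluoro group and para to a large group, gives a 1.3-fold lower number from compound 3 to compound 4 (0.12 log units; within the scatter) and so leaves compound 3 and compound 4 indistinguishable on this read-out. Among these compounds, this is the first measured step that adds a chloro group to the shared core, and it shows that this position can carry a chlorine atom with a clearance number that stays within the scatter of the parent compound. Nothing measured here offers an explanation for this result.

Going by these compounds, whether a group such as methoxy, an amine or a carboxylic acid at this position would give a step beyond the scatter remains open. Also open, on these data alone, is whether chloro here gives a similar step on a ring that carries no fluoro group.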